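This account rests on a few compounds, and the source may have more. Where it says the series, first, only, none or still open, it means among the compounds named here.

Compound 1, with the structure `COc1ccc(-c2cc(OC)cc(C(=O)Nc3nn[nH]n3)n2)cc1`, is tested in a functional assay on the whole organism with Rattus norvegicus as the target, at a dose of 3 mg/kg by the oral route (a lower number here means a weaker effect, a higher number a stronger effect of the compound at the dose given), and gives 60%. Within the data shown here, of the three compounds with numbers so far, compound 1 stands lowest: compound 3, `CCCCc1ccc(-c2cc(OC)cc(C(=O)Nc3nn[nH]n3)n2)cc1`, gives 61%, and compound 2, `CCCc1ccc(-c2cc(OC)cc(C(=O)Nc3nn[nH]n3)n2)cc1`, gives 93%. The step of a number 1 percentage points higher from compound 1 to compound 3 (within the scatter) lies within the scatter, while a number 33 percentage points higher from compound 1 to compound 2 (beyond the scatter) and a number 32 percentage points lower from compound 2 to compound 3 (beyond the scatter) are both large.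

Compound 4, `COc1ccc(-c2cccc(C(=O)Nc3nn[nH]n3)n2)cc1`, differs from compound 1 by one change: hydrogen in place of methoxy on an aromatic carbon. This change sits on the shared core, not on the outer phenyl ring, where all three measured steps took place. None of those steps therefore bears directly on it; they only show that the read-out in this assay can swing widely with a small structural change. Among the measured compounds shown here, removing a methoxy group from the core has no measured counterpart here, so the expectation rests on compound 1 alone. For compound 4 the estimate is a somewhat lower value, 45%, in the range 15% to 75%, which is expected to mean a step of a number 15 percentage points lower from compound 1 to compound 4 (beyond the scatter).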

Compound 4, a percentage reported as inhibition, in the whole organism at one dose (the size of the read-out at that dose, not a potency): 36%
The estimate for compound 4 lay 9 percentage points above the measured number; low and high end bracket the measured number.
By their numbers in this assay, from the lowest: compound 4; then compounds 1 and 3 (each within the scatter of the next); then compound 2.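

On the shared core, at the place opposite the ring nitrogen, hydrogen in place of methoxy gives a number 24 percentage points lower from compound 1 to compound 4 (beyond the scatter) in this assay. Among these compounds, all the earlier steps lay on the outer phenyl ring, so this is the first sign that the core position also matters for the read-out at this dose, with the methoxy compound reading higher in this one pair. No measurement here says what lies behind the drop.

On these data alone, whether another group at this place, such as an ethoxy group, a chlorine atom or an amine, would match or exceed methoxy remains open. Also open, as far as these compounds go, is whether the same change on compound 2, with its propyl group on the outer ring, would give a step of similar size.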